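Swapping Phenyl for Vinyl on an Inactive Scaffold

A few compounds are considered here, and "the series" means these few. Any claim that something is new, unique, unknown or untested is made for them only; others in the source may bear on it.

The setting is a functional assay on KYSE-410 cells (Homo sapiens) for antiproliferative activity, read by MTT assay, with a stated time of 72 h; on this read-out higher numbers stand for weaker inhibition and lower numbers for stronger inhibition. Of the compounds shown here, three have been measured so far, and none of them produced a number. Compound 1 `O=C(c1ccnc2cc(Br)ccc12)N1CCCCC1` gives > 20000 nM, which is a limit of the assay rather than a measured value. Compound 2 `O=C(Nc1ccc(Cl)cc1)c1ccnc2cc(Br)ccc12` likewise gives > 20000 nM, again a limit. Compound 3 `O=C(Nc1cccc(F)c1)c1cc(=O)[nH]c2cc(-c3ccccc3)ccc12` stands at > 20000 nM in this assay, also a limit and not a number. There is therefore nothing to rank among the three, a point summed up by the limit of > 20000 nM in this assay, at which 3 of the 3 values shown sit.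

Compound 4 `C=Cc1ccc2c(C(=O)Nc3cccc(F)c3)cc(=O)[nH]c2c1` has not yet been measured in this assay. It differs from compound 3 in one place: vinyl in place of phenyl on an aromatic carbon. Among the measured compounds shown here, no pair of measured compounds differs in a single place, so no measured step exists to lean on, and the starting point, compound 3, is itself only a limit in this assay.

The step from a number no higher from compound 3 to compound 4 (the limit leaves the size open) is expected to be no change beyond the usual scatter. Compound 4 is accordingly estimated at about 20000 nM, with a range from 6000 nM to 60000 nM, and most likely the assay will once more report only a limit.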

Compound 4, half-maximal inhibitory concentration: 13600 nM
The estimate for compound 4 lay 1.5-fold (0.17 log units) above the measured number; low and high end bracket the measured number.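

Replacing phenyl with vinyl on this aromatic carbon gives, in this assay, an at least 1.4-fold lower number from compound 3 to compound 4 (0.16 log units; that floor lies within the scatter). Among the compounds shown here, the floor of that step lies within the usual scatter, and compound 3 carries only a limit, so the true size of the change cannot be read; the step shows only that the number is lower by some unknown amount that may be small. Even so, compound 4, at 13600 nM, is the only compound shown with a real number, so this position can carry a group of two carbons instead of a six-membered ring and still give a measurable result. Every other compound stays at the limit: the limit of > 20000 nM in this assay, at which 3 of the 4 values shown sit.

The compounds shown leave open whether the double bond of the vinyl group matters or whether a small group of any kind would serve as well, a question that an ethyl group on the same carbon would help to settle. They also leave open how an amine, a carboxylic acid or a longer chain at this position would change the number.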